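Compound 3 to compound 4: chloro replaces methoxy

The source may report more compounds than this note shows. Statements on the series, on what has been measured and on what is new or still open speak of the compounds shown alone.

compound 1 `CC(C)(C)OC(=O)N1CCN(c2c(C(=O)NCc3ccc(F)cc3)nc(Br)c3cccnc23)CC1`: 3000 nM
compound 2 `COc1cccc(CNC(=O)c2nc(Br)c3cccnc3c2N[C@H]2CC[C@H](N)CC2)c1`: 6000 nM
compound 3 `COc1ccc(CNC(=O)c2nc(Br)c3cccnc3c2N[C@H]2CC[C@H](N)CC2)cc1`: 5000 nM

In a functional assay on SK-BR-3 cells (Homo sapiens) for cytotoxicity, read by MTT assay, with a stated time of 72 h (a higher number here means a weaker inhibitor, a lower number a stronger inhibitor), compound 3 gives 5000 nM and lies within the usual scatter of both compound 1 and compound 2, so no real order can be read between it and either neighbour. The next compound, compound 4 `N[C@H]1CC[C@H](Nc2c(C(=O)NCc3ccc(Cl)cc3)nc(Br)c3cccnc23)CC1`, keeps the rest of compound 3 and changes one group: chloro in place of methoxy on an aromatic carbon. In words, this is chloro in place of methoxy on an aromatic carbon, para to a large group, so 4-methoxybenzyl becomes 4-chlorobenzyl.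

Among the measured compounds shown here, only one measured step touches this aromatic ring: a 1.2-fold lower number from compound 2 to compound 3 (0.08 log units; within the scatter), and it lies within the scatter. That step moves the methoxy group and does not replace it, so it offers only indirect guidance about chloro. Compound 1 differs from compound 3 in more than one place and gives no clean comparison. With so little evidence, no step beyond the scatter is expected in this assay, in either direction. The estimated change is small: a 1.3-fold lower number from compound 3 to compound 4 (0.10 log units; within the scatter) and no clear shift is expected. For compound 4 the expected value is 4000 nM, with an estimated range from 1500 nM to 10000 nM and the measurement still to come.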

Compound 4, half-maximal inhibitory concentration: 2000 nM
The estimate for compound 4 lay 2.0-fold (0.30 log units) above the measured number; measured number inside the range.
By their numbers in this assay, from the lowest: compounds 4, 1, 3 and 2 (each within the scatter of the next, the first and the last beyond it).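

In this assay, putting chloro in place of methoxy on this aromatic carbon, para to a large group, gives a 2.5-fold lower number from compound 3 to compound 4 (0.40 log units; beyond the scatter), a modest step and the first at this ring to pass beyond the scatter. Taking 3-methoxyphenyl to 4-chlorophenyl gives a 3.0-fold lower number from compound 2 to compound 4 (0.48 log units; beyond the scatter), also modest, while moving the methoxy group alone gave a 1.2-fold lower number from compound 2 to compound 3 (0.08 log units; within the scatter), which stayed within the scatter; among these three compounds, then, only the steps that bring in chloro can be read as real changes. The data shown offer no measurement that would explain the step seen with chloro.

These compounds leave open whether chloro itself matters or whether other groups on this carbon, such as bromo, trifluoromethyl, an amine or a carboxylic acid, or plain hydrogen, would give a similar number. From the compounds shown here alone, it is also open how 3-chlorophenyl would compare with 4-chlorophenyl, and compound 1, which carries fluoro on this ring, cannot settle the matter, as it also differs from compound 4 elsewhere on the shared core.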